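Notes on compound 4: 3-methylpyridin-4-yl in place of phenyl

This account rests on a few compounds, and the source may have more. Where it says the series, first, only, none or still open, it means among the compounds named here.

Measured compounds in a functional assay on MCF7 cells (Homo sapiens) for cytotoxicity, read by CellTiter-Glo, with a stated time of 5 days; a lower number here means a stronger inhibitor, a higher number a weaker inhibitor:
- compound 1 `CC/C(=C(/c1ccc(/C=C/C(=O)O)cc1)c1ccc2[nH]cnc2c1)c1ccccc1`: 1180 nM
- compound 2 `CC/C(=C(/c1ccc(/C=C/C(=O)O)cc1)c1ccc2[nH]ncc2c1)c1ccccc1`: 6 nM
- compound 3 `CC/C(=C(/c1ccc(/C=C/C(=O)O)c(C)c1)c1ccc2[nH]ncc2c1)c1ccccc1`: 14 nM

Compound 2 gives the lowest number of the three. The step of a 200-fold lower number from compound 1 to compound 2 (2.29 log units; beyond the scatter) is large; the step of a 2.3-fold higher number from compound 2 to compound 3 (0.37 log units; beyond the scatter) is modest. Compound 2 is therefore the strongest of the measured set, with both other compounds beyond the scatter from it.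

Compound 4 `CC/C(=C(/c1ccc(/C=C/C(=O)O)cc1)c1ccc2[nH]ncc2c1)c1ccncc1C` differs from compound 2 in one place: 3-methylpyridin-4-yl in place of phenyl on a double-bonded chain carbon bound to a double-bonded chain carbon and a saturated chain carbon. For the measured compounds named here, no measured step changes the phenyl on that chain carbon; the only measured steps concern the bicyclic ring (large) and a methyl on an aromatic carbon of the other ring (modest). Neither bears directly on this change, so the expectation rests on the starting point of compound 2 and on the modest size of the nearest comparable change, that from compound 2 to compound 3.

For compound 4 a modest weakening is expected, a 2.5-fold higher number from compound 2 to compound 4 (0.40 log units; beyond the scatter), with the number estimated at 15 nM and the likely range from 4 nM to 60 nM.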

Compound 4, half-maximal inhibitory concentration: 16 nM
For compound 4 the middle estimate is 1.1-fold (0.03 log units) below the measured one, within the range that was stated.
By their numbers in this assay, from the lowest: compound 2; then compounds 3 and 4 (each within the scatter of the next); then compound 1.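

In this assay, this is the first change shown at the phenyl on a double-bonded chain carbon bound to a double-bonded chain carbon and a saturated chain carbon, and a 2.7-fold higher number from compound 2 to compound 4 (0.43 log units; beyond the scatter) marks it as a modest step. The step is far smaller than a 200-fold lower number from compound 1 to compound 2 (2.29 log units; beyond the scatter) and shows that the position can take 3-methylpyridin-4-yl, with its ring nitrogen and methyl, while the number stays in the same low range as that of compound 2. No supporting data bear on the origin of this step.

On these data alone, how much of the step belongs to the ring nitrogen and how much to the methyl remains open; a pyridinyl without the methyl and a methylphenyl would separate the two. Also open, as far as these compounds go, is how this position responds to an amine or a longer chain on the ring.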